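Ethyl for Cyclopropyl on the Triazole Nitrogen

The compounds below may be only part of what the source reports. "The series", "measured", "known", "first", "only" and "open" are said of these compounds alone.

Of the compounds shown here, two have so far been tested in an assay on membranes from Jurkat cells for displacement of a labelled ligand from Sigma intracellular receptor 2 (Homo sapiens), read by scintillation counting, with a stated time of 1 h; on this read-out lower numbers stand for stronger inhibition and higher numbers for weaker inhibition. Compound 1 `Cn1nc(CN2CCCC2)nc1-c1ccc2ccsc2c1` gives > 1000 nM in this assay, which is a limit of the assay rather than a number. Among the measured compounds shown here, compound 2 `CC(C)(C)c1ccc(-c2nc(CN3CCCC3)nn2C2CC2)cc1` gives 750 nM in this assay, the only numerical value obtained, while the other result sits at the limit of > 1000 nM in this assay, at which 1 of the 2 values shown sits. Compound 3 `CCn1nc(CN2CCCC2)nc1-c1ccc(C(C)(C)C)cc1` has not yet been measured. It differs from compound 2 by ethyl in place of cyclopropyl on an aromatic nitrogen. For the measured compounds named here, no pair of measured compounds differs in one place, so the size of such a step is not fixed by anything measured here; the account expects no shift beyond the usual scatter, or at most a slight weakening. The step from compound 2 to compound 3 is estimated at a 1.3-fold higher number from compound 2 to compound 3 (0.12 log units; within the scatter). Compound 3 is accordingly expected to give 1000 nM in this assay, within a range from 400 nM to 2500 nM, with a real chance that only a limit is reported.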

Compound 3, inhibition constant: 1710 nM
Estimate against measurement, compound 3: 1.7-fold (0.23 log units) below; measured number inside the range.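

In this assay, among the compounds shown here, the one step that can be read falls on the aromatic nitrogen of the five-membered ring, where ethyl in place of cyclopropyl gives a 2.3-fold higher number from compound 2 to compound 3 (0.36 log units; beyond the scatter). The opening of the account could fix no size for a change here, and this pair now shows that the position is not indifferent to its substituent: even an exchange as limited as this one, in which the three-membered ring gives way to an open chain, moves the number beyond the usual scatter, though only modestly, and in this pair the cyclopropyl compound holds the lower number. Nothing measured here says whether the loss of the ring or some other difference between the two groups lies behind this step.

On these data alone, whether an isopropyl or a cyclobutyl group on the same nitrogen would follow cyclopropyl or ethyl stays open, since one pair fixes no trend at this position. As far as these compounds go, compound 1 gives > 1000 nM, which is a limit of the assay, and it differs from compound 2 and compound 3 in more than one place, so the part played by its nitrogen substituent also remains open.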